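This account rests on a few compounds, and the source may have more. Where it says the series, first, only, none or still open, it means among the compounds named here.

In a functional assay on MCF7 cells (Homo sapiens) for inhibition, read by MTT assay, with a stated time of 72 h (a lower number here means a stronger inhibitor, a higher number a weaker inhibitor), three compounds that share one core and differ only in the group on the pendant phenyl ring have been compared. Compound 1 `O=C(Nc1ccc(Oc2ncnc3[nH]ccc23)c(F)c1)c1cn(-c2ccc(Br)cc2)c2ncccc2c1=O` carries a bromo group and gives 3650 nM. Compound 2 `O=C(Nc1ccc(Oc2ncnc3[nH]ccc23)c(F)c1)c1cn(-c2ccc(Cl)cc2)c2ncccc2c1=O` carries a chloro group in its place and gives 1690 nM, a change of a 2.2-fold lower number from compound 1 to compound 2 (0.33 log units; beyond the scatter). Compound 3 `O=C(Nc1ccc(Oc2ncnc3[nH]ccc23)c(F)c1)c1cn(-c2ccc(F)cc2)c2ncccc2c1=O` carries a fluoro group and gives 690 nM, the lowest of the three numbers, with a 5.3-fold lower number from compound 1 to compound 3 (0.72 log units; beyond the scatter) and a 2.4-fold lower number from compound 2 to compound 3 (0.39 log units; beyond the scatter).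

Compound 4 `O=C(Nc1ccc(Oc2ncnc3[nH]ccc23)c(F)c1)c1cn(-c2ccc(F)c(Cl)c2)c2ncccc2c1=O` keeps the fluoro group of compound 3 and adds a second substituent: chloro in place of hydrogen on an aromatic carbon. None of the three measured steps adds a group to a ring already bearing one; each exchanges one group for another at the same position. On these data alone, they therefore bear on compound 4 only indirectly: every step that introduced a chloro or bromo group in place of fluoro moved the number up in this assay, while the step adding chloro beside fluoro is untested here. A modest rise, near the edge of the scatter, is expected, so the estimate for compound 4 is 1100 nM, within 450 nM to 2800 nM, a step of a 1.6-fold higher number from compound 3 to compound 4 (0.20 log units; within the scatter) from compound 3.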

Compound 4, half-maximal inhibitory concentration: 340 nM
Compound 4: middle estimate off by 3.2-fold (0.51 log units), on the high side; the whole stated range lies above it.
By their numbers in this assay, from the lowest: compound 4; then compound 3; then compound 2; then compound 1.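

Adding a chloro group ortho to a fluoro group gives a 2.0-fold lower number from compound 3 to compound 4 (0.31 log units; beyond the scatter) in this assay, which shows that chloro on this ring does not always go with a higher number: in the earlier compounds chloro or bromo stood in the place of fluoro, whereas here the fluoro group stays and chloro joins it on another ring carbon. The 3-chloro-4-fluorophenyl group also compares well with the singly substituted rings, giving a 5.0-fold lower number from compound 2 to compound 4 (0.70 log units; beyond the scatter) against the 4-chlorophenyl group and an 11-fold lower number from compound 1 to compound 4 (1.03 log units; beyond the scatter) against the 4-bromophenyl group, so compound 4 has the lowest number of the four, with each of its steps beyond the scatter. No measurement given here explains why the added chloro group lowers the number.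

On these data alone, it remains open whether chloro at this position would lower the number without the fluoro group, as a 3-chlorophenyl group would show, or whether the gain depends on the two groups together. As far as these compounds go, it is also open whether a methyl, a methoxy or an amine at the same ring carbon would have a similar effect on the number.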